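This account rests on a few compounds, and the source may have more. Where it says the series, first, only, none or still open, it means among the compounds named here.

Three compounds share one core, and the readout is a functional assay on the whole organism (blood, strain Sprague-Dawley albino) with Rattus norvegicus as the target, with stated times of 30 min and 5 h, at a dose of 100 mg/kg by the oral route; on this read-out lower numbers stand for less inhibition and higher numbers for more inhibition at the one dose given (going by the name of the read-out). For the measured compounds named here, compound 1 `COc1ccc(-c2cc(-c3ccccc3)no2)c(OCCCN2CCCCC2)c1` is the only one with a number: in this assay compound 1 gives 14.7%, a small effect at the single dose. Compound 2 `COc1ccc(-c2cc(-c3ccccc3)no2)c(OCC(=O)O)c1` was run in this assay, and for compound 2 the result reads "not determined" (no result reported), so compound 2 stands nowhere on the numbers shown; its place in this series cannot be read from the data and no step between measured compounds is available.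

The unmeasured compound 3 `CCN(CC)CC(O)COc1cc(OC)ccc1-c1cc(-c2ccccc2)no1` arises from compound 2 by a single change, (2-(diethylamino)-1-hydroxyethyl in place of carboxy on a saturated chain carbon bound to an oxygen on an aromatic ring). Going by the values given here, because no step is given, the size of the step in this assay can only be guessed, and the guess is that compound 3 will sit within the usual scatter of compound 1, with no clear direction. Compound 3 is expected to give about 18%, between 0% and 40%, because compound 1 gives 14.7% in this assay and also carries a nitrogen-bearing chain on the same aromatic oxygen.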

Compound 3, a percentage reported as inhibition, in the whole organism at one dose (the size of the read-out at that dose, not a potency): 11.6%
Estimate against measurement, compound 3: 6.4 percentage points above; the measured number falls inside the stated range.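

Putting 2-(diethylamino)-1-hydroxyethyl in place of 2-(piperidin-1-yl)ethyl on a saturated chain carbon bound to an oxygen on an aromatic ring gives, in this assay, a number 3.1 percentage points lower from compound 1 to compound 3 (within the scatter), so two differently built amine chains at this place cannot be told apart on this read-out. For the compounds shown here, this is the first comparison available at this position: an open diethylamino end carrying a hydroxy group on the chain reads the same as a piperidine ring, within the noise of the measurement, while the step from compound 2 to compound 3 cannot be read, since compound 2 has no number. No measurement is available that bears on why the two chains read alike.

Compound 1 and compound 3 differ in both the amine and the hydroxy group at once, so a 3-(diethylamino)propyl chain without the hydroxy group would be needed to separate the two parts of the change. Also open, on these data alone, is whether a morpholine ring or a dimethylamino group at the end of the chain, or an amide in place of the amine, would read any differently at this dose.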